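The source may report more compounds than this note shows. Statements on the series, on what has been measured and on what is new or still open speak of the compounds shown alone.

Measured so far in a functional assay on the whole organism (strain Kunming) with Mus musculus as the target, with a stated time of 0.5 h; on this read-out higher numbers stand for an effect only at larger amounts of compound and lower numbers for an effect already at smaller amounts:

- compound 1 `COc1ccccc1/C=C/C(=O)OC/C=C/c1cc(OC)c(OC)cc1OC`: 625 umol/kg
- compound 2 `COc1cc(OC)c(OC)cc1/C=C/COC(=O)/C=C/c1cccc(Br)c1`: > 461 umol/kg (a limit, not a number)

Compound 2 stands only as a limit, > 461 umol/kg. Within the data shown here, that leaves compound 1 at 625 umol/kg as the only actual number.

Compound 3 `COc1cc(OC)c(OC)cc1/C=C/COC(=O)/C=C/c1ccccc1Cl` follows from compound 2 by one change: 2-chlorophenyl in place of 3-bromophenyl on a double-bonded chain carbon bound to a double-bonded chain carbon. In words, this is 2-chlorophenyl in place of 3-bromophenyl on a double-bonded chain carbon bound to a double-bonded chain carbon.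

Among the measured compounds shown here, the one measured step bearing on this change is a step that the limit leaves unreadable from compound 1 to compound 2, made on the same chain carbon. It gives no size to carry over, and so it sets no direction either. For the measured compounds named here, with nothing readable to build on, no shift beyond the scatter is expected in this assay, and the estimate stays close to the only number available, that of compound 1 at 625 umol/kg. The expected change is a step that the limit leaves unreadable from compound 2 to compound 3. For compound 3 the estimated value is 600 umol/kg, with an expected range of 250 umol/kg to 1400 umol/kg.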

Compound 3, dose for half-maximal effect: 385 umol/kg
Estimate against measurement, compound 3: 1.6-fold (0.19 log units) above; the measured number falls inside the stated range.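

In this assay, among these compounds, 2-chlorophenyl in place of 3-bromophenyl on a double-bonded chain carbon bound to a double-bonded chain carbon gives an at least 1.1-fold lower number from compound 2 to compound 3 (0.07 log units; that floor lies within the scatter), which is the first readable step at this position, though it is only a floor. Chloro in place of methoxy on an aromatic carbon gives a 1.6-fold lower number from compound 1 to compound 3 (0.21 log units; within the scatter), so the two actual numbers in the series do not separate in this assay, and a halogen on this phenyl ring is so far not told apart from methoxy. The step from compound 1 to compound 2 cannot be read, and the step from compound 2 to compound 3 has no upper size because compound 2 stands as a limit only: the limit of > 461 umol/kg in this assay, at which 1 of the 3 values shown sits.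

On these data alone, the true size of the bromo-to-chloro change stays open, since the position of the halogen and its identity change together in that step and cannot be separated here. As far as these compounds go, whether an amine or a carboxylic acid on this phenyl ring would move the read-out beyond the scatter also remains open.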